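Nitrogen substituent variation on a shared benzimidazole-type acid core

A few compounds are considered here, and "the series" means these few. Any claim that something is new, unique, unknown or untested is made for them only; others in the source may bear on it.

Measured compounds in an assay on isolated protein for agonist activity at Bile acid receptor (Homo sapiens), read by TR-FRET; on this read-out lower numbers stand for an effect already at smaller amounts and higher numbers for an effect only at larger amounts of compound:
compound 1, `CCC(CC)n1c(-c2ccc(OCc3c(-c4c(Cl)cccc4Cl)noc3C(C)C)cc2)nc2ccc(C(=O)O)cc21`, 26.5 nM
compound 2, `CC(C)c1onc(-c2c(Cl)cccc2Cl)c1COc1ccc(-c2nc3ccc(C(=O)O)cc3n2C(C)C)cc1`, 56.7 nM
compound 3, `CC(=O)N1CCC(n2c(-c3ccc(OCc4c(-c5c(Cl)cccc5Cl)noc4C(C)C)cc3)nc3ccc(C(=O)O)cc32)CC1`, "not determined" (no result reported)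

Three compounds share one core and differ only in the group on the aromatic nitrogen. Compound 1 carries pentan-3-yl and gives 26.5 nM in this assay. Compound 2 carries isopropyl and gives 56.7 nM. Going by the values given here, the one step within the measured set, a 2.1-fold higher number from compound 1 to compound 2 (0.33 log units; beyond the scatter), shows that a smaller branched group on that nitrogen costs a modest amount of potency. Compound 3 carries 1-acetylpiperidin-4-yl on the same nitrogen; for compound 3 no number is available in this assay, so it stands nowhere on the scale and the step to compound 4 cannot be anchored to it.

Compound 4, `CC(C)c1onc(-c2c(Cl)cccc2Cl)c1COc1ccc(-c2nc3ccc(C(=O)O)cc3n2C2CCCCCC2)cc1`, differs from compound 3 in one place: cycloheptyl in place of 1-acetylpiperidin-4-yl on an aromatic nitrogen. The entering cycloheptyl is an all-carbon ring, larger than either of the branched alkyls of compound 1 and compound 2. Among the compounds with values here, the only measured step bears indirectly: going from isopropyl to pentan-3-yl recovers potency, so a still larger hydrocarbon group is expected to sit near compound 1 rather than compound 2. Compound 4 is therefore expected to give about 25 nM, within 8 nM to 80 nM.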

Compound 4, half-maximal effective concentration: 113 nM
For compound 4 the middle estimate is 4.5-fold (0.66 log units) below the measured one; the whole stated range lies below it.
By their numbers in this assay, from the lowest: compound 1; then compounds 2 and 4 (each within the scatter of the next).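

In this assay, cycloheptyl on the aromatic nitrogen does not hold the level reached with pentan-3-yl, the change giving a 4.3-fold higher number from compound 1 to compound 4 (0.63 log units; beyond the scatter) in this comparison. Against isopropyl the same ring gives a 2.0-fold higher number from compound 2 to compound 4 (0.30 log units; within the scatter) as its result, so compound 2 and compound 4 cannot be told apart, and compound 1 alone stands clear of both others, with the lowest number of the three. The step from isopropyl to pentan-3-yl therefore does not extend into a simple trend across these all-carbon groups, and nothing available explains the result.

The steps involving compound 3 cannot be read, as it has no number, so 1-acetylpiperidin-4-yl, with the hetero atom in its six-membered ring, remains unplaced among these nitrogen groups. From the compounds shown here alone, it also remains open whether cyclopentyl or cyclohexyl on this nitrogen would fall with compound 1 or with compound 2 and compound 4, and so whether pentan-3-yl marks a narrow optimum or one point on a broader range.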